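The compounds below may be only part of what the source reports. "The series", "measured", "known", "first", "only" and "open" are said of these compounds alone.

Measured so far in a functional assay on HeLa cells (Homo sapiens) for cytotoxicity, read by MTT assay, with a stated time of 24 h; a lower number here means a stronger inhibitor, a higher number a weaker inhibitor:
- compound 1 `C/C(=N\NC(=O)/C(C#N)=C/c1ccc(Br)cc1)c1c(O)c2ccc(O)cc2oc1=O`: 10600 nM
- compound 2 `C/C(=N\NC(=O)/C(C#N)=C/c1cccc([N+](=O)[O-])c1)c1c(O)c2ccc(O)cc2oc1=O`: 24600 nM

Compound 2, at 24600 nM, has the higher of the two numbers in this assay and is the weaker inhibitor of the pair. The next structure is compound 3 `C/C(=N\NC(=O)/C(C#N)=C/c1ccccc1Cl)c1c(O)c2ccc(O)cc2oc1=O`, with 2-chlorophenyl in place of 3-nitrophenyl on a double-bonded chain carbon bound to a double-bonded chain carbon.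

Among the compounds with values here, only one measured step bears on this change. It is a 2.3-fold higher number from compound 1 to compound 2 (0.37 log units; beyond the scatter), a modest step at the same place and beyond the scatter. The entering group, like the 4-bromophenyl of compound 1 , carries a halogen on the phenyl ring, whereas the leaving group is the one found in the higher-numbered compound 2 . Within the data shown here, no measured compound carries 2-chlorophenyl, and a single step cannot separate the identity of the group from its position on the ring. A modest move to a lower number is therefore expected, with wide uncertainty. The expected change is a 1.9-fold lower number from compound 2 to compound 3 (0.28 log units; within the scatter). For compound 3 the estimate is 13000 nM, with an expected range of 6000 nM to 28000 nM.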

Compound 3, half-maximal inhibitory concentration: 11800 nM
The estimate for compound 3 lay 1.1-fold (0.04 log units) above the measured number; low and high end bracket the measured number.
By their numbers in this assay, from the lowest: compounds 1 and 3 (each within the scatter of the next); then compound 2.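

In this assay, a 2.1-fold lower number from compound 2 to compound 3 (0.32 log units; beyond the scatter), so compound 2 now stands apart from both halogen-bearing compounds, with a step beyond the scatter to each, and is the weakest of the three. The two halogen-bearing groups give numbers that cannot be told apart: a 1.1-fold higher number from compound 1 to compound 3 (0.05 log units; within the scatter), even though 2-chlorophenyl and 4-bromophenyl differ in both the halogen and where it sits on the phenyl ring, so at this place in the series neither difference shows up as a change beyond the scatter in this pair. No measured evidence accounts for the gap between compound 2 and the other two compounds.

Within the data shown here, with only three compounds, the separate contributions of the halogen and its location remain open, as does whether the higher number of compound 2 belongs to the nitro group or to its location on the ring; 4-chlorophenyl and 4-nitrophenyl would each address one of these questions through a single change. Also open, going by these compounds, is how this place responds to an unsubstituted phenyl or to a phenyl bearing an amine or a carboxylic acid.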